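The source may report more compounds than this note shows. Statements on the series, on what has been measured and on what is new or still open speak of the compounds shown alone.

Of the compounds shown here, three sharing one core have been measured in a functional assay on microsomes for inhibition, with a stated time of 1 h; a higher number here means a weaker inhibitor, a lower number a stronger inhibitor. Compound 1 `CCOC(=O)c1cnn(-c2nc(-c3ccco3)c(C#N)c(=O)n2C)c1N` gives 116 ug/mL, compound 2 `CCOC(=O)c1cnn(-c2nc(-c3cccs3)c(C#N)c(=O)n2C)c1N` gives 97 ug/mL and compound 3 `CCOC(=O)c1cnn(-c2nc(-c3ccccc3Cl)c(C#N)c(=O)n2C)c1N` gives 102 ug/mL. Compound 3 thus stands within the scatter of both others, and the three cannot be ranked. Compound 4 `CCOC(=O)c1cnn(-c2nc(-c3cccc(O)c3O)c(C#N)c(=O)n2C)c1N` is not yet measured and differs from compound 3 in one group: 2,3-dihydroxyphenyl in place of 2-chlorophenyl on an aromatic carbon. Among the measured compounds shown here, three measured steps bear on this exchange, all made at the same aromatic carbon: a 1.2-fold lower number from compound 1 to compound 2 (0.08 log units; within the scatter), a 1.1-fold lower number from compound 1 to compound 3 (0.06 log units; within the scatter) and a 1.1-fold higher number from compound 2 to compound 3 (0.02 log units; within the scatter). Each lies within the scatter, so no exchange at this place has yet moved the number in this assay. None of them brings in a 2,3-dihydroxyphenyl group, however, so the data hold no direct test of it, and the range must stay wide. Resting on a 1.1-fold higher number from compound 2 to compound 3 (0.02 log units; within the scatter) and its two companions, no step beyond the scatter is expected for compound 4. The expected step is a 1.1-fold lower number from compound 3 to compound 4 (0.03 log units; within the scatter). The estimate for compound 4 is 95 ug/mL, with an expected range from 45 ug/mL to 190 ug/mL.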

Compound 4, half-maximal inhibitory concentration: 49 ug/mL
The estimate for compound 4 lay 1.9-fold (0.29 log units) above the measured number; low and high end bracket the measured number.
By their numbers in this assay, from the lowest: compounds 4, 2, 3 and 1 (each within the scatter of the next, the first and the last beyond it).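

In this assay this aromatic carbon, where the earlier exchanges all stayed within the scatter, now shows a step beyond it: 2,3-dihydroxyphenyl gives a 2.1-fold lower number from compound 3 to compound 4 (0.32 log units; beyond the scatter) in place of 2-chlorophenyl and a 2.4-fold lower number from compound 1 to compound 4 (0.37 log units; beyond the scatter) in place of furan-2-yl, and both steps are modest. Against thiophen-2-yl the exchange gives a 2.0-fold lower number from compound 2 to compound 4 (0.30 log units; within the scatter) and stays just within the scatter, so compound 4 separates from only two of the three earlier compounds. No measurement at hand offers an explanation for these steps.

The compounds shown do not tell whether both hydroxyl groups are needed, or whether a single hydroxyl, a methoxy group or an amine on the phenyl ring would give a similar number. As far as these compounds go, whether the step would hold with a carboxylic acid in place of the ethyl ester also stays open.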